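Phenyl ring substitution and cytotoxicity in one hydrazone series

A few compounds are considered here, and "the series" means these few. Any claim that something is new, unique, unknown or untested is made for them only; others in the source may bear on it.

compound 1 `C/C(=N\NC(=O)COc1cccc2ccccc12)c1ccc(C#N)cc1Br` — 20 ug/mL
compound 2 `C/C(=N\NC(=O)COc1cccc2ccccc12)c1ccc(O)cc1O` — > 100 ug/mL

Two compounds of the series have been run through an ADME assay on HEL cells (Homo sapiens) for cytotoxicity; on this read-out lower numbers stand for higher toxicity in this test and higher numbers for lower toxicity in this test. Compound 1 gives 20 ug/mL. Compound 2 reaches only a limit of the test, > 100 ug/mL, so for compound 2 only a bound is known and no number; this is the limit of > 100 ug/mL in this assay, at which 1 of the 2 values shown sits. Among the measured compounds shown here, the one measured step is an at least 5.0-fold higher number from compound 1 to compound 2 (0.69 log units; beyond the scatter), 2,4-dihydroxyphenyl in place of 2-bromo-4-cyanophenyl on a carbon with a double bond to nitrogen.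

Compound 3 `C/C(=N\NC(=O)COc1cccc2ccccc12)c1ccccc1O` is not yet measured. From compound 2 it differs by hydrogen in place of hydroxy on an aromatic carbon, the hydroxy leaving from the aromatic carbon that is meta to a hydroxy group and para to a large group; cut one bond further out, 2,4-dihydroxyphenyl becomes 2-hydroxyphenyl.

For the measured compounds named here, only the step from compound 1 to compound 2 bears on this, and loosely: it exchanged the whole substitution pattern and raised the number at least modestly. Taking away one of the two hydroxy groups undoes part of that exchange, so in this assay a step toward a lower number of at most modest size, or none beyond the scatter, is expected. The estimate for compound 3 is 80 ug/mL, within 30 ug/mL to 200 ug/mL, an expected step of an at least 1.2-fold lower number from compound 2 to compound 3 (0.09 log units; that floor lies within the scatter).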

Compound 3, minimum cytotoxic concentration: 20 ug/mL
The estimate for compound 3 lay 4.0-fold (0.60 log units) above the measured number; the measured number lies below the stated range.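

In this assay, the loss of this one hydroxy group gives an at least 5.0-fold lower number from compound 2 to compound 3 (0.69 log units; beyond the scatter), so the high number of the series depends on this position and not merely on the general exchange of ring substituents seen earlier. The 2-hydroxyphenyl and 2-bromo-4-cyanophenyl compounds stand level, with no change at the digits printed from compound 1 to compound 3 (within the scatter), which means that keeping one hydroxy group on the ring is not enough to hold the number seen with 2,4-dihydroxyphenyl. For compound 2, the value of > 100 ug/mL is a limit and not a number, so the size of the step from it is only a floor: the limit of > 100 ug/mL in this assay, at which 1 of the 3 values shown sits.

From the compounds shown here alone, how far compound 2 lies past its limit stays open, and with it the true size of the effect of this hydroxy group. The compounds shown also leave open whether a methoxy group, an amine or a carboxylic acid at this position would give a number like that of the hydroxy group or one like that of hydrogen.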